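This account rests on a few compounds, and the source may have more. Where it says the series, first, only, none or still open, it means among the compounds named here.

The study gathers two measured compounds and one awaiting measurement. Compound 1 `Cc1cc(Cl)cc(-c2ccnc3cc(CN4C(=O)C5CC5C4=O)sc23)c1C[C@@H]1CNC[C@@H](C)O1` gives 60 nM in an assay on RKO cells for inhibition of ubiquitin carboxyl-terminal hydrolase 7 (Homo sapiens), read by a luciferase reporter, with a stated time of 18 h (on this read-out lower numbers stand for an effect already at smaller amounts and higher numbers for an effect only at larger amounts of compound), and compound 2 `Cc1cc(Cl)cc(-c2ccnc3cc(CN4C(=O)CCC4=O)sc23)c1OC1CCNCC1` gives 400 nM in this assay. Compound 1 stands at the lower of the two numbers, and the gap to compound 2 lies beyond the scatter of repeated measurements. Compound 3 `Cc1cc(Cl)cc(-c2ccnc3cc(CN4C(=O)C5CC5C4=O)sc23)c1C[C@H]1OCCN[C@@H]1C` is built from the same atoms as compound 1, joined differently: the change is 3-methylmorpholin-2-yl in place of 6-methylmorpholin-2-yl on a saturated chain carbon bound to an aromatic carbon. Among the measured compounds shown here, no measured pair in the set shows what such a shift of the methyl within the morpholine ring does, so the size of the step is open. The account expects the change to cost a little, with a step of a 1.7-fold higher number from compound 1 to compound 3 (0.22 log units; within the scatter) that may well stay within the usual scatter. On that basis compound 3 is estimated to give 100 nM in this assay, within a range from 30 nM to 400 nM.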

Compound 3, half-maximal effective concentration: 210 nM
Estimate against measurement, compound 3: 2.1-fold (0.32 log units) below; the measured number falls inside the stated range.
By their numbers in this assay, from the lowest: compound 1; then compounds 3 and 2 (each within the scatter of the next).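

In this assay, among the compounds shown here, 3-methylmorpholin-2-yl in place of 6-methylmorpholin-2-yl on a saturated chain carbon bound to an aromatic carbon gives a 3.5-fold higher number from compound 1 to compound 3 (0.54 log units; beyond the scatter) and provides the only pair in the set that differs in one place. The step is modest, yet it shows that the number responds to this exchange even though the two groups match in heavy atoms, hydrogen-bond donors and acceptors, and number of defined stereocentres. Nothing measured here accounts for the step.

The compounds shown do not separate the shift of the methyl from any contribution of the stereocentres. They also leave open what an unsubstituted morpholin-2-yl, a 5-methylmorpholin-2-yl or a piperazine ring would give at this place.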